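A Methyl Added to the Central Phenyl of Compound 2

This account rests on a few compounds, and the source may have more. Where it says the series, first, only, none or still open, it means among the compounds named here.

Of the compounds shown here, three built on one shared core have been measured in a functional assay on Ehrlich cells (Homo sapiens) for cytotoxicity, read by MTT assay, with a stated time of 48 h; a lower number here means a stronger inhibitor, a higher number a weaker inhibitor. Compound 1 `Cc1noc2c1N=C(c1ccc(Cl)cc1)CC(c1ccccc1)C2C(c1ccccc1)C1c2onc(C)c2N=C(c2ccc(Cl)cc2)CC1c1ccccc1` gives 58.5 ug/mL. Compound 2 `Cc1noc2c1N=C(c1ccccc1)CC(c1ccccc1)C2C(c1ccccc1)C1c2onc(C)c2N=C(c2ccccc2)CC1c1ccccc1` gives 66.5 ug/mL. Compound 3 `Cc1noc2c1N=C(c1cccs1)CC(c1ccccc1)C2C(c1ccccc1)C1c2onc(C)c2N=C(c2cccs2)CC1c1ccccc1` gives 26.1 ug/mL. On these numbers compound 2 stands at the highest value of the three. Its nearest neighbour is compound 1, whose number lies within the scatter of that of compound 2, so the two cannot be told apart. The number of compound 3 lies beyond the scatter and is the lower of the pair, so on the numbers compound 3 is the stronger inhibitor of the two in this assay.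

Compound 4 `Cc1ccc(C(C2c3onc(C)c3N=C(c3ccccc3)CC2c2ccccc2)C2c3onc(C)c3N=C(c3ccccc3)CC2c2ccccc2)cc1` has not yet been measured in this assay. It differs from compound 2 in a single place:

methyl in place of hydrogen on an aromatic carbon

The change adds one carbon, a methyl in place of hydrogen on an aromatic carbon of a six-membered aromatic ring of carbon only, para to a large group; read one bond further out, the phenyl becomes a 4-methylphenyl. For the measured compounds named here, no measured pair among compounds 1 to 3 carries this same change, so the data give no step to rest on. The step of a 1.1-fold lower number from compound 2 to compound 4 (0.04 log units; within the scatter) is expected to be small, with no clear direction beyond the scatter. Compound 4 is therefore estimated at 60 ug/mL, with a range from 30 ug/mL to 120 ug/mL.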

Compound 4, half-maximal inhibitory concentration: 48.2 ug/mL
The estimate for compound 4 lay 1.2-fold (0.10 log units) above the measured number; measured number inside the range.
By their numbers in this assay, from the lowest: compounds 3, 4, 1 and 2 (each within the scatter of the next, the first and the last beyond it).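

For the compounds shown here, compounds 1 to 3 all carry an unsubstituted phenyl at this place, so the step from compound 2 is the first reading of any change there. In this assay the methyl on the aromatic carbon, para to a large group, gives a 1.4-fold lower number from compound 2 to compound 4 (0.14 log units; within the scatter) and so leaves compound 2 and compound 4 indistinguishable: on this core, turning the phenyl into a 4-methylphenyl does not move the number by more than repeated measurements would. Nothing available here speaks to why the methyl has so little effect on the reading.

The compounds shown leave open whether an amine, a carboxylic acid or a longer chain such as butyl at this same place would carry the number beyond the scatter, since a single methyl says nothing about larger or charged groups. They also leave open whether the same methyl would behave alike on compound 3, which carries a different group elsewhere on the shared core and has the lowest number of the series at 26.1 ug/mL in this comparison.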